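Trifluoromethyl for chloro on the phenoxy ring

A few compounds are considered here, and "the series" means these few. Any claim that something is new, unique, unknown or untested is made for them only; others in the source may bear on it.

Compound 2 `CNC(=O)c1cccc(Cn2nc(C)c(NC(=O)c3ccc(COc4ccc(Cl)cc4)cc3)c2C)c1` gives 4200 nM in a functional assay on MIA PaCa-2 cells (Homo sapiens) for antiproliferative activity, read by MTT assay, with a stated time of 72 h (a lower number here means that less compound is needed, a higher number that more compound is needed for the effect), and it stands close to compound 1 `CNC(=O)c1cccc(Cn2nc(C)c(NC(=O)c3ccc(COc4ccccc4)cc3)c2C)c1`, which gives 6200 nM in the same assay; the two are separated by a 1.5-fold lower number from compound 1 to compound 2 (0.17 log units; within the scatter). Compound 3 `CNC(=O)c1cccc(Cn2nc(C)c(NC(=O)c3ccc(COc4ccc(C(F)(F)F)cc4)cc3)c2C)c1` is not yet measured; it differs from compound 2 by trifluoromethyl in place of chloro on an aromatic carbon. For the measured compounds named here, the only step that bears on it, a 1.5-fold lower number from compound 1 to compound 2 (0.17 log units; within the scatter), was small, so a change beyond the scatter is not expected from compound 2 to compound 3, which is estimated as a 1.2-fold lower number from compound 2 to compound 3 (0.08 log units; within the scatter). Compound 3 is therefore expected to give 3500 nM in this assay, estimated between 1400 nM and 9000 nM.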

Compound 3, half-maximal effective concentration: 800 nM
Compound 3: middle estimate off by 4.4-fold (0.64 log units), on the high side, and the stated range ends above it.
By their numbers in this assay, from the lowest: compound 3; then compounds 2 and 1 (each within the scatter of the next).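

At this place on the phenoxy ring, the choice of substituent turned out to matter in this assay, which the chloro compound had not shown. Trifluoromethyl in place of chloro brings a 5.3-fold lower number from compound 2 to compound 3 (0.72 log units; beyond the scatter), and trifluoromethyl in place of hydrogen brings a 7.8-fold lower number from compound 1 to compound 3 (0.89 log units; beyond the scatter), so this ring position is not indifferent to what it carries. Nothing measured here explains the difference between trifluoromethyl and chloro.

On these data alone, whether a nitrile or a methoxy group at this place would behave like trifluoromethyl stays open. So does whether trifluoromethyl would have the same effect elsewhere on this ring.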